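The source may hold more compounds than are shown below. What is called first, only, known or untested is meant among the compounds shown, and "the series" means these compounds.

In a functional assay on the whole organism for positive allosteric modulation, with Mus musculus as the target (on this read-out higher numbers stand for an effect only at larger amounts of compound and lower numbers for an effect already at smaller amounts), compound 1 (`CCC(=O)N(c1ccc(Cl)cc1)C1CCCC1N(C)C`) gives > 50 mg/kg as a limit of the assay and not a number. Compound 1 thus stands at the limit of > 50 mg/kg in this assay, at which 1 of the 3 values shown sits, and offers no exact starting point. In this assay compound 2 (`CCC(=O)N(c1ccc(C)c(Cl)c1)C1CCCC1N(C)C`) gives 2 mg/kg and compound 3 (`CCC(=O)N(c1ccc(Cl)c(C)c1)C1CCCC1N(C)C`) gives 10 mg/kg as measured numbers. Compound 4 (`CCC(=O)N(c1ccc(C(C)=O)cc1)C1CCCC1N(C)C`) differs from compound 1 by acetyl in place of chloro on an aromatic carbon with acetyl in place of chloro on an aromatic carbon, para to a large group. Among the compounds with values here, no measured step replaces chloro. The nearest evidence is an at least 5.0-fold lower number from compound 1 to compound 3 (0.69 log units; beyond the scatter) for methyl in place of hydrogen on an aromatic carbon, and it bears only indirectly. It shows that compound 1 can move off its limit with a change on the aromatic ring, so a move to a lower number is expected, though compound 4 may also remain at a limit. The estimated move is an at least 2.0-fold lower number from compound 1 to compound 4 (0.30 log units; that floor lies within the scatter) in the same direction as that measured step. In this assay the expected value for compound 4 is 25 mg/kg within an estimated range from 6 mg/kg to 100 mg/kg at the upper end.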

Compound 4, dose for half-maximal effect: > 50 mg/kg
Compound 4 was reported as a limit; the forecaster's own chance of this, stated with the estimate: 40%; at least 2.0-fold (0.30 log units) between middle value and limit.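

In this assay compound 1 and compound 4 both stand at a limit of the assay and not at a number, so the step between them cannot be read: the limit of > 50 mg/kg in this assay, at which 2 of the 4 values shown sit. The compounds shown leave open whether acetyl in place of chloro changes the dose needed at all, and in which direction.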